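The source may hold more compounds than are shown below. What is called first, only, known or untested is meant among the compounds shown, and "the series" means these compounds.

Three quinone-type compounds were measured in an ADME assay on HaCaT cells (Homo sapiens) for cytotoxicity, read by MTT assay, with a stated time of 72 h; a higher number here means a weaker inhibitor, a lower number a stronger inhibitor. Compound 1 `CC(C)(C)C1=CC(=O)C=C(NCc2ccccc2)C1=O` gives 21000 nM, and compound 2 `CCNC1=CC(=O)C=C(C(C)(C)C)C1=O` gives 30000 nM. The change from compound 2 to compound 1 is phenyl in place of methyl on a saturated chain carbon bound to an amine nitrogen

and made a step of a 1.4-fold lower number from compound 2 to compound 1 (0.15 log units; within the scatter). Compound 3 `CCNC1=CC(=O)C(C(C)(C)C)=CC1=O` gives 75000 nM; the difference between its core and that of compound 2 is not broken down here. Compound 4 `CC(C)(C)C1=CC(=O)C(NCc2ccccc2)=CC1=O` has not yet been measured; it differs from compound 3 by phenyl in place of methyl on a saturated chain carbon bound to an amine nitrogen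

which is the same change seen from compound 2 to compound 1, in the same place. Because that earlier step was a 1.4-fold lower number from compound 2 to compound 1 (0.15 log units; within the scatter), compound 4 is expected to lie close to compound 3, with an estimated step of a 1.4-fold lower number from compound 3 to compound 4 (0.14 log units; within the scatter). Compound 4 is therefore estimated at 54000 nM, within a range from 25000 nM to 110000 nM.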

Compound 4, half-maximal inhibitory concentration: 28000 nM
Estimate against measurement, compound 4: 1.9-fold (0.29 log units) above, within the range that was stated.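

In this assay, putting phenyl in place of methyl on a saturated chain carbon bound to an amine nitrogen gives a 2.7-fold lower number from compound 3 to compound 4 (0.43 log units; beyond the scatter) on the core of compound 3. Set beside the same change on the core of compound 2, this step cannot be told apart from the earlier one: the same change on two cores in this assay, a 1.4-fold lower number (0.15 log units; within the scatter) from compound 2 to compound 1 and a 2.7-fold lower number (0.43 log units; beyond the scatter) from compound 3 to compound 4, 1.9-fold (0.27 log units) apart, within the scatter of two such steps. Among the compounds shown here, the two cores therefore give no sign that the core alters the outcome of this change, though two pairs in one assay set no rule for any other core and do not explain why only one step lies beyond the scatter.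

The compounds shown leave open how a longer chain, an amine or a carboxylic acid would read in place of phenyl on that chain carbon.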